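One Bromo Group Added to Compound 2

The source may report more compounds than this note shows. Statements on the series, on what has been measured and on what is new or still open speak of the compounds shown alone.

Compound 2, `COc1ccccc1C(=O)Nc1ccc(Sc2nc3ccccc3s2)c(Cl)c1`, was tested in an assay for inhibition of HSP60/HSP10 (Homo sapiens), with a stated time of 60 min; a higher number here means a weaker inhibitor, a lower number a stronger inhibitor. In this assay compound 2 gives only the limit > 100000 nM, which is a boundary of the assay and not a measured number. Compound 1, `COc1c(Br)cc(Br)cc1C(=O)Nc1ccc(Sc2nc3ccccc3s2)c(Cl)c1`, carries two bromo groups where compound 2 carries none, and in this assay compound 1 also reaches only the limit > 100000 nM. The step that the two limits leave unreadable from compound 1 to compound 2 cannot be read in size or direction, since both of its ends sit at the limit of > 100000 nM in this assay, at which 2 of the 2 values shown sit.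

Compound 3, `COc1c(Br)cccc1C(=O)Nc1ccc(Sc2nc3ccccc3s2)c(Cl)c1`, differs from compound 2 in one spot: bromo in place of hydrogen on an aromatic carbon. Going by the values given here, of the measured steps only the one from compound 1 to compound 2 touches this part of the molecule, and its size is unknown. There is therefore no basis for expecting a change beyond the scatter in this assay in either direction, and the most likely outcome is that compound 3 again reports only a limit. Compound 3 is expected to show the step that the limit leaves unreadable from compound 2 to compound 3. The estimate for compound 3 is 150000 nM, with a range from 30000 nM to 600000 nM.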

Compound 3, half-maximal inhibitory concentration: > 100000 nM
Compound 3: only a limit was reported; the forecaster's own chance of this, stated with the estimate: 85%; the middle value lies beyond the limit too.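

In this assay compound 3 gives > 100000 nM, which is again a limit and not a number. Going by these compounds alone, no step among compound 1, compound 2 and compound 3 can be read in size or direction, because all three stop at the same boundary: the limit of > 100000 nM in this assay, at which 3 of the 3 values shown sit. The compounds shown leave open whether bromo in place of hydrogen changes inhibition at all.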